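The source may report more compounds than this note shows. Statements on the series, on what has been measured and on what is new or still open speak of the compounds shown alone.

Two compounds of the series have numbers in a functional assay on PC-3 cells (Homo sapiens) for cytotoxicity, read by MTT assay, with a stated time of 48 h; on this read-out higher numbers stand for weaker inhibition and lower numbers for stronger inhibition. Compound 1 `CC(C)n1c(/C=C2/C(=O)Nc3ccc(F)cc32)nc2ccccc21` gives 20800 nM in this assay. Compound 2 `Cn1c(/C=C2/C(=O)Nc3ccc(F)cc32)nc2ccccc21` gives 34300 nM in this assay. Going by the values given here, the single step between them, a 1.6-fold higher number from compound 1 to compound 2 (0.22 log units; within the scatter), is methyl in place of isopropyl on an aromatic nitrogen. Among the compounds with values here, compound 2 and compound 1 therefore lie within the scatter of each other, and neither stands apart on the numbers so far.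

Compound 3 `Cn1c(/C=C2/C(=O)Nc3ccc(Cl)cc32)nc2ccccc21` has not yet been measured in this assay. It differs from compound 2 by chloro in place of fluoro on an aromatic carbon. Within the data shown here, no measured step touches this change; the only step available concerns the group on an aromatic nitrogen and was within the scatter, so it gives no guidance on a halogen exchange on the carbon ring. With nothing in the series pointing to a shift, the expected step of a 1.2-fold lower number from compound 2 to compound 3 (0.09 log units; within the scatter) in this assay is none beyond the scatter. Compound 3 is accordingly estimated at 28000 nM in this assay, with a range of 9000 nM to 85000 nM.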

Compound 3, half-maximal inhibitory concentration: > 50000 nM
Compound 3: no number, only a limit (the forecaster's own chance of this, stated with the estimate: 10%); middle value at least 1.7-fold (0.25 log units) from the limit.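

Going by these compounds alone, this is the first read on the carbon ring of the shared core, as the earlier step changed only the group on an aromatic nitrogen. In this assay, compound 3 gives no number, only a limit: the limit of > 50000 nM in this assay, at which 1 of the 3 values shown sits.

On these data alone, the step can be read only as a floor, an at least 1.4-fold higher number from compound 2 to compound 3 (0.16 log units; that floor lies within the scatter), so its true size remains unknown. Chloro in place of fluoro at this position, on the six-membered aromatic ring of carbon only, therefore shows no sign of stronger inhibition.

Still open, as far as these compounds go, is whether a smaller or differently built group at this carbon, such as methoxy, nitrile or an amine, would bring the number down. Also open, from the compounds shown here alone, is whether chloro gives the same picture with isopropyl on the aromatic nitrogen, the group carried by compound 1.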